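This account rests on a few compounds, and the source may have more. Where it says the series, first, only, none or still open, it means among the compounds named here.

The compounds here share one core, and the part followed in this piece is the group attached to the nitrogen on the aromatic ring. Compound 1, `O=C(NCc1ccc(F)cc1)c1nc(Br)c2cccnc2c1NCc1ccc(F)cc1`, carries a (4-fluorobenzyl)amino group there. In a functional assay on MDA-MB-435 cells (Homo sapiens) for cytotoxicity, read by MTT assay, with a stated time of 72 h (a higher number here means a weaker inhibitor, a lower number a stronger inhibitor), compound 1 gives only a limit, > 20000 nM, not a number. Compound 2, `N[C@H]1CC[C@H](Nc2c(C(=O)NCc3cccc(C(F)(F)F)c3)nc(Br)c3cccnc23)CC1`, and compound 3, `N[C@H]1CC[C@H](Nc2c(C(=O)NCc3ccccc3)nc(Br)c3cccnc23)CC1`, carry instead a cyclohexyl ring bearing an amino group on that nitrogen. In this assay compound 2 gives 4200 nM. Compound 3 gives 7000 nM in this assay. Among the compounds with values here, the one measured step between them, a 1.7-fold higher number from compound 2 to compound 3 (0.22 log units; within the scatter), lies on the amide side of the molecule and is within the scatter, so it says little about the change followed here.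

Compound 4, `NCCCCCCNc1c(C(=O)NCc2ccc(F)cc2)nc(Br)c2cccnc12`, is made from compound 1 by the change (5-aminopentyl in place of 4-fluorophenyl on a saturated chain carbon bound to a nitrogen on an aromatic ring). Within the data shown here, no measured step covers exactly this exchange. Compound 1 sits at the limit of > 20000 nM in this assay, at which 1 of the 3 values shown sits. Compound 2 and compound 3, each with an amino group in the part attached to that nitrogen, give numbers well inside the measurable range. On that basis compound 4 is expected to gain potency, by an at least 2.8-fold lower number from compound 1 to compound 4 (0.45 log units; beyond the scatter), though the limit for compound 1 leaves the size of that step uncertain. Compound 4 is estimated at 7000 nM, with a range from 2500 nM to 20000 nM.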

Compound 4, half-maximal inhibitory concentration: 6000 nM
Compound 4: the middle estimate sits 1.2-fold (0.07 log units) above what was measured; the measured number falls inside the stated range.
By their numbers in this assay, from the lowest: compounds 2, 4 and 3 (each within the scatter of the next). At a limit, above all of these: compound 1.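

Within the data shown here, this is the first step here in which only the group on the nitrogen changes, and the exchange of 4-fluorobenzyl for 6-aminohexyl gives an at least 3.3-fold lower number from compound 1 to compound 4 (0.52 log units; beyond the scatter) in this assay while everything else in the molecule stays the same. It shows that this group needs no aromatic ring or fluorine to give a measurable value here, since an open chain with neither reaches one. Compound 1 gives > 20000 nM and this is a limit and not a number, so the true step may be larger than the one printed, because the comparison starts from that limit: the limit of > 20000 nM in this assay, at which 1 of the 4 values shown sits.

The step swaps a ring with fluorine for a chain with an amine in a single exchange, so the compounds shown leave open whether losing the ring or gaining the amine matters more. A plain hexyl group would separate those two changes, while a shorter or longer chain ending in an amine, or a chain ending in a carboxylic acid, would test how much the length and the amine itself count.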